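This account rests on a few compounds, and the source may have more. Where it says the series, first, only, none or still open, it means among the compounds named here.

Compound 1 `NCc1ccc(C(=O)Nc2ccncc2F)cc1-c1cccc(NC(=O)c2cccc(C(=O)O)c2)c1`: > 2 h (a limit)
Compound 2 `CC(C)OC(=O)c1cccc(NC(=O)c2cccc(-c3cc(C(=O)Nc4ccncc4F)ccc3CN)c2)c1`: 0.567 h

Among the measured compounds shown here, in an ADME assay on a cell-free system (plasma, Homo sapiens) for metabolic stability, read by LC-MS (a higher number here means that the compound lasts longer, a lower number that the compound disappears faster), compound 2 gives 0.567 h, the only true number so far. Compound 1 gives > 2 h, which is a limit of the assay and not a number. Compound 3 `NCc1ccc(C(=O)Nc2ccncc2F)cc1-c1cccc(C(=O)Nc2ccccc2)c1` has not been measured. It derives from compound 2 by a single change, hydrogen in place of isopropoxycarbonyl on an aromatic carbon, meta to a large group.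

For the measured compounds named here, no measured pair shows this change alone, so its size has to be judged indirectly. Going by the values given here, the only guide is compound 1, which also lacks isopropoxycarbonyl and gives > 2 h, again a limit. Compound 1 differs from compound 3 elsewhere too, so this guide is a loose one. A longer half-life in this assay is therefore expected, by a step beyond the usual scatter, and the estimated change is a 4.4-fold higher number from compound 2 to compound 3 (0.64 log units; beyond the scatter). The estimate for compound 3 is 2.5 h, with an expected range of 1 h to 6 h.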

Compound 3, half-life: > 2 h
Compound 3: only a limit was reported (the forecaster's own chance of this, stated with the estimate: 65%); the middle value is on the limit's open side.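

Among the compounds shown here, for the first time, a single change at this place can be read: hydrogen in place of isopropoxycarbonyl on an aromatic carbon, meta to a large group, gives an at least 3.5-fold higher number from compound 2 to compound 3 (0.54 log units; beyond the scatter) in this assay. Compound 1 pointed the same way, but it differs from compound 2 in more than one place, whereas the pair of compound 2 and compound 3 ties the shorter half-life of compound 2 to the isopropoxycarbonyl group alone. Compound 3 gives > 2 h, which is a limit of the assay and not a number.

As far as these compounds go, the step between compound 1 and compound 3 cannot be read, and how far compound 3 lies past its limit remains unknown: the limit of > 2 h in this assay, at which 2 of the 3 values shown sit. It also remains open whether the shorter half-life goes with any ester at this place or with the isopropyl part in particular, and what a methyl ester, an ethyl ester or an amine on the same aromatic carbon would give.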